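Boronic acid series: working notes toward compound 4

This account rests on a few compounds, and the source may have more. Where it says the series, first, only, none or still open, it means among the compounds named here.

Measured so far:
compound 1 `O=C(/C=C/c1ccc(I)cc1)c1ccc(OCB(O)O)cc1`: 38000 nM
compound 2 `O=C(O)COc1ccc(C(=O)/C=C/c2ccc(Cl)c(Cl)c2)cc1`: 13000 nM
compound 3 `O=C(/C=C/c1ccc(B(O)O)cc1)c1ccc[nH]1`: 38000 nM

In a functional assay on MCF-10A cells (Homo sapiens) for inhibition (on this read-out higher numbers stand for weaker inhibition and lower numbers for stronger inhibition), compound 1 gives 38000 nM, level with compound 3 at the digits shown and together the highest of the three numbers; compound 2 stands lowest, and its gap to compound 1 lies beyond the scatter. Among the measured compounds shown here, no two measured compounds differ in one place, so no single-change step is available to lean on. Compound 4 `O=C(/C=C/c1ccc(I)cc1)c1ccc(B(O)O)cc1` differs from compound 1 by a group of 3 heavy atoms (1 boron, 2 oxygen; no ring) in place of a group of 5 heavy atoms (1 carbon, 1 boron, 3 oxygen; no ring), on an aromatic carbon. For the measured compounds named here, with no comparable step measured, the expected step of a 1.3-fold lower number from compound 1 to compound 4 (0.10 log units; within the scatter) is none beyond the scatter, in either direction. Compound 4 is therefore estimated at 30000 nM, with a range from 10000 nM to 90000 nM.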

Compound 4, half-maximal inhibitory concentration: 75000 nM
Compound 4: middle estimate off by 2.5-fold (0.40 log units), on the low side; measured number inside the range.
By their numbers in this assay, from the lowest: compound 2; then compounds 1, 3 and 4 (each within the scatter of the next).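

In this assay the series now has its first single-change step: the group of 3 heavy atoms in place of the group of 5 heavy atoms, on an aromatic carbon para to a large group, gives a 2.0-fold higher number from compound 1 to compound 4 (0.30 log units; within the scatter) and so does not separate the two compounds. On this read-out, the two boron-bearing groups cannot be told apart at this position. No measurement at hand speaks to a reason for this step. As far as these compounds go, whether an amine or a longer chain in that place would move the number beyond the scatter remains open.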